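Stripping the amide aryl ring down to unsubstituted phenyl

The source may hold more compounds than are shown below. What is called first, only, known or untested is meant among the compounds shown, and "the series" means these compounds.

compound 1 `COc1cc(-c2nn(-c3cccc(NC(=O)c4cccc(C(F)(F)F)c4)c3)cc2-c2ccncc2)ccc1Cl` — a functional assay on HOP-92 cells (Homo sapiens) for inhibition, read by sulforhodamine B assay, with a stated time of 48 h; a lower number here means that less compound is tolerated, a higher number that more compound is tolerated: > 50000 nM, a limit of the assay
compound 2 `COc1cc(-c2nn(-c3cccc(NC(=O)c4ccc(Cl)c(C(F)(F)F)c4)c3)cc2-c2ccncc2)ccc1Cl` — this assay: > 32500 nM, a limit of the assay

In this assay compound 1 gives > 50000 nM, which is a limit rather than a number. Compound 2 gives > 32500 nM, which is likewise a limit. Going by the values given here, the single step between measured compounds, a step that the two limits leave unreadable from compound 1 to compound 2, has no readable size because the limit of > 32500 nM in this assay, at which 1 of the 2 values shown sits, and the limit of > 50000 nM in this assay, at which 1 of the 2 values shown sits, mark where its two ends sit. Compound 2 therefore stands only at a limit, with no measured value of its own.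

Compound 3 `COc1cc(-c2nn(-c3cccc(NC(=O)c4ccccc4)c3)cc2-c2ccncc2)ccc1Cl` differs from compound 2 by phenyl in place of 4-chloro-3-(trifluoromethyl)phenyl on a carbonyl carbon. No measured step bears directly on this change; the only step shown, that from compound 1 to compound 2, concerns a chloro on the same ring and is itself unreadable. There is thus no ground to expect a step in this assay beyond the scatter, in either direction, and the most likely outcome is again a limit. Compound 3 is estimated at 40000 nM, within a range from 12000 nM to 120000 nM. The expected step that the limit leaves unreadable from compound 2 to compound 3 is accordingly set near nothing.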

Compound 3, concentration lethal to 50% of the cells: > 100000 nM
Compound 3 was reported as a limit; the forecaster's own chance of this, stated with the estimate: 70%; middle value at least 2.5-fold (0.39 log units) away from the limit.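

In this assay compound 3 gives > 100000 nM, which is a limit of the assay. Going by these compounds alone, as compound 1, compound 2 and compound 3 all stand only at limits, no step among them can be read. The compounds shown leave open whether any of these changes on the amide aryl ring alters the reading in this assay at all.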